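Switching the hydroxyl position on a terpyridine-like inhibitor

A few compounds are considered here, and "the series" means these few. Any claim that something is new, unique, unknown or untested is made for them only; others in the source may bear on it.

Measured so far:
compound 1, `Oc1ccc(-c2cc(-c3ccco3)cc(-c3ccc(O)cc3)n2)cc1`, 100%
compound 2, `Oc1ccc(-c2cc(-c3ccccn3)cc(-c3cccc(O)c3)n2)cc1`, 2.4%

In an assay on isolated protein for inhibition of DNA topoisomerase 1 (Homo sapiens), with a stated time of 30 min, tested at 100 uM (on this read-out lower numbers stand for a weaker effect and higher numbers for a stronger effect at the one concentration tested), compound 1 gives 100%, whereas compound 2 gives 2.4%. Compound 2 therefore stands lowest of the two numbers, and its gap to compound 1 is well beyond the usual scatter of this assay. Among the measured compounds shown here, the two differ in more than one place, so no single step between them can be read off.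

Compound 3, `Oc1ccc(-c2cc(-c3ccccn3)cc(-c3ccc(O)cc3)n2)cc1`, has the same atoms as compound 2 but joined differently: 4-hydroxyphenyl in place of 3-hydroxyphenyl on an aromatic carbon. Compound 3 thus carries the pair of 4-hydroxyphenyl groups seen in compound 1, while keeping the pyridin-2-yl group of compound 2.

For the measured compounds named here, with only two measured compounds there is no direct precedent for this change. Because compound 1, which shares the two 4-hydroxyphenyl groups, reaches 100%, an upward step is expected, though the different third group leaves it uncertain; the estimated step is a number 42.6 percentage points higher from compound 2 to compound 3 (beyond the scatter). Compound 3 is expected to give 45%, within a range from 5% to 95%.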

Compound 3, a percentage reported as inhibition, at one concentration (the size of the read-out at that concentration, not a potency): 1.4%
Beside the measured number, compound 3's estimate is 43.6 percentage points above it; the measured number lies below the stated range.
By their numbers in this assay, from the lowest: compounds 3 and 2 (each within the scatter of the next); then compound 1.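

In this assay, placing 4-hydroxyphenyl instead of 3-hydroxyphenyl on the aromatic carbon next to the ring nitrogen gives a number 1 percentage points lower from compound 2 to compound 3 (within the scatter), so with pyridin-2-yl present, this change of hydroxyl position does not separate the two compounds. Carrying the two 4-hydroxyphenyl groups of the furan compound is thus not enough to retain its effect: pyridin-2-yl in place of furan-2-yl gives a number 98.6 percentage points lower from compound 1 to compound 3 (beyond the scatter), a large step tied in this pair to that one change of group. No measurement here bears on why that group change matters so much while the hydroxyl shift does not.

As far as these compounds go, what remains open is whether the hydroxyl position is just as silent when furan-2-yl occupies the third position, since the shift has been read only against a pyridin-2-yl background, where both values lie near the bottom of the scale. From the compounds shown here alone, it is also open whether the high value belongs specifically to furan-2-yl or would extend to other groups at that place, such as thiophen-2-yl or a plain phenyl ring.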